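A few compounds are considered here, and "the series" means these few. Any claim that something is new, unique, unknown or untested is made for them only; others in the source may bear on it.

Measured compounds:
Compound 1 `CC(C)=CCC/C(C)=C/COc1cc(=O)n(CCCO)c2c1CC(CC=C(C)C)C(C)(C)C2`, inhibition 18.4%.
Compound 2 `CC(C)=CCC/C(C)=C/COc1cc(=O)n(CCCO)c2c1CC(C/C=C(\C)CCC=C(C)C)C(C)(C)C2`, inhibition 3.1%.

In a functional assay on PANC-1 cells (Homo sapiens) for inhibition, read by MTT assay, with a stated time of 24 h, tested at 10 uM (on this read-out lower numbers stand for less inhibition and higher numbers for more inhibition at the one concentration tested (going by the name of the read-out)), compound 1 gives 18.4%, and compound 2 gives 3.1%. Among the measured compounds shown here, the one step between them, a number 15.3 percentage points lower from compound 1 to compound 2 (beyond the scatter), concerns 3-methylbut-2-en-1-yl in place of hydrogen on a saturated chain carbon bound to a double-bonded chain carbon. For the measured compounds named here, compound 2 thus stands lowest of the two numbers, with compound 1 as its only neighbour.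

Compound 3 `CC(C)=CCC/C(C)=C/CC1Cc2c(OCCCNC(=O)c3ccco3)cc(=O)n(CCCO)c2CC1(C)C` has not yet been measured in this assay. It differs from compound 2 in this way: 2-(((furan-2-yl)carbonyl)amino)ethyl in place of 2,6-dimethylhepta-1,5-dien-1-yl on a saturated chain carbon bound to an oxygen on an aromatic ring. Going by the values given here, no measured step touches the saturated chain carbon bound to an oxygen on an aromatic ring, so the step from compound 1 to compound 2 bears on it only as a sign of how much a single change to the side chains can move the read-out. With the starting number already low, the expectation is for a small rise at most, within or close to the scatter; the expected step is a number 6.9 percentage points higher from compound 2 to compound 3 (within the scatter). Compound 3 is therefore estimated at 10%, between 0% and 30%.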

Compound 3, a percentage reported as inhibition, at one concentration (the size of the read-out at that concentration, not a potency): 2.8%
Compound 3: middle estimate off by 7.2 percentage points, on the high side; the range from low to high includes it.
By their numbers in this assay, from the lowest: compounds 3 and 2 (each within the scatter of the next); then compound 1.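

In this assay, among the compounds shown here, the step at the saturated chain carbon bound to an oxygen on an aromatic ring, a number 0.3 percentage points lower from compound 2 to compound 3 (within the scatter), is the first measured change at this place. It exchanges 2,6-dimethylhepta-1,5-dien-1-yl, which has no ring and 0 hydrogen-bond donors or acceptors, for 2-(((furan-2-yl)carbonyl)amino)ethyl, with its five-membered aromatic ring, 1 hydrogen-bond donor and 2 hydrogen-bond acceptors, and even so different a group leaves the two compounds within the scatter of each other, whereas the earlier step, at the other side chain, went beyond it. For the compounds shown here, no supporting measurement bears on why the two groups read alike, and with compound 2 already at 3.1%, this pair shows only that the exchange gave no gain on this background.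

The compounds shown leave open whether the same exchange would read differently with 3-methylbut-2-en-1-yl on the other side chain, as in compound 1, where the starting number is 18.4%. They also leave open whether a basic amine or a carboxylic acid at the end of this chain, or a longer chain carrying the furan amide, would move the read-out at all.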